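Ether substituent variation at the aromatic oxygen of the shared core

A few compounds are considered here, and "the series" means these few. Any claim that something is new, unique, unknown or untested is made for them only; others in the source may bear on it.

Working notes on the series. Compound 1 `Cc1n[nH]c2nc(-c3ccc(NS(=O)(=O)c4cc(Cl)ccc4F)cc3)nc(OCC(CO)CO)c12` and compound 2 `Cc1n[nH]c2nc(-c3ccc(NS(=O)(=O)c4cc(Cl)ccc4F)cc3)nc(OC3CC(C)(C)N(C)C(C)(C)C3)c12` share the whole core and differ only in the group on the aromatic oxygen. In an assay for inhibition of serine/threonine-protein kinase Sgk1 (Homo sapiens), with stated times of 30 min and 60 min, in the presence of a further agent that is not named here (a higher number here means a weaker inhibitor, a lower number a stronger inhibitor), compound 1 gives 1 nM, and compound 2 gives 2 nM. Among the measured compounds shown here, the one step between measured compounds is a 2.0-fold higher number from compound 1 to compound 2 (0.30 log units; within the scatter), so the two numbers cannot be told apart, and compound 2 stands beside compound 1 with nothing in the data that separates them.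

Compound 3 `CCN1CCCC(Oc2nc(-c3ccc(NS(=O)(=O)c4cc(Cl)ccc4F)cc3)nc3[nH]nc(C)c23)C1` is the next member, differing from compound 2 only as 1-ethylpiperidin-3-yl in place of 1,2,2,6,6-pentamethylpiperidin-4-yl on an oxygen on an aromatic ring. For the measured compounds named here, the single step that bears on this position, a 2.0-fold higher number from compound 1 to compound 2 (0.30 log units; within the scatter), shows that two very different groups on this oxygen gave numbers within the scatter of each other. Going by the values given here, no measured step reports a change beyond the scatter at this position, and nothing speaks for a large move in this assay.

Compound 3 is therefore expected to stay near compound 2, with an estimated step of a 1.5-fold higher number from compound 2 to compound 3 (0.18 log units; within the scatter). The expected value for compound 3 in this assay is 3 nM, within a range from 1 nM to 10 nM.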

Compound 3, half-maximal inhibitory concentration: 6 nM
The estimate for compound 3 lay 2.0-fold (0.30 log units) below the measured number, within the range that was stated.
By their numbers in this assay, from the lowest: compounds 1 and 2 (each within the scatter of the next); then compound 3.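

In this assay, this position now shows changes beyond the scatter, though modest ones: a 3.0-fold higher number from compound 2 to compound 3 (0.48 log units; beyond the scatter), and a 6.0-fold higher number from compound 1 to compound 3 (0.78 log units; beyond the scatter). The group on the oxygen therefore has some bearing on the number, even when the group that leaves and the group that enters each hold a six-membered non-aromatic ring with 1 hetero atom and carry no net charge, and compound 3 sits above both compound 1 and compound 2, which remain within the scatter of each other. No measurement here bears on why the number rises.

The step to compound 3 combines a change of attachment from piperidin-4-yl to piperidin-3-yl, a change from the N-methyl to the N-ethyl group and the loss of the four ring methyl groups, so 1-ethylpiperidin-4-yl and 1-methylpiperidin-3-yl are the groups that could separate these parts. The compounds shown also leave open how an open-chain amine such as 2-(dimethylamino)ethyl or a chain ending in a carboxylic acid would read on this oxygen.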